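Swapping a hydroxycyclohexyl ring for an oxanyl ring

The compounds below may be only part of what the source reports. "The series", "measured", "known", "first", "only" and "open" are said of these compounds alone.

Compound 2 `COc1ccc(-c2c(-c3ccc(OC)cc3)n(Cc3ccccc3)c3ncn([C@@H]4CCCC[C@H]4O)c(=N)c23)cc1` carries a 2-hydroxycyclohexyl group on an aromatic nitrogen of the shared core. In an ADME assay for permeability, using PAMPA, with a stated time of 30 min, at pH 7.4 (a lower number here means that the compound crosses the layer more slowly, a higher number that the compound crosses the layer faster), compound 2 gives > 1000 10^-6 cm/s, which is a limit of the assay and not a number. Its close relative compound 1 `COc1ccc(-c2c(-c3ccc(OC)cc3)n(Cc3ccccc3)c3ncn(CCCO)c(=N)c23)cc1` carries a 3-hydroxypropyl chain on an aromatic nitrogen. In this assay compound 1 gives > 1000 10^-6 cm/s, again a limit rather than a number. The step that the two limits leave unreadable from compound 1 to compound 2 therefore cannot be read in size or direction. Compound 3 `COc1ccc(-c2c(-c3ccc(OC)cc3)n(Cc3ccccc3)c3ncn(C4CCOCC4)c(=N)c23)cc1` has not yet been measured; it differs from compound 2 by oxan-4-yl in place of 2-hydroxycyclohexyl on an aromatic nitrogen. For the measured compounds named here, only one measured step exists, a step that the two limits leave unreadable from compound 1 to compound 2, and it gives no size, so no measured step bears directly on this change. What the numbers do show is the limit of > 1000 10^-6 cm/s in this assay, at which 2 of the 2 values shown sit. For compound 3 the expected step of a number no higher from compound 2 to compound 3 (the limit leaves the size open) is none beyond the scatter. The value of compound 3 is estimated at 1000 10^-6 cm/s, between 400 10^-6 cm/s and 1000 10^-6 cm/s, and is most likely to be reported once more only as the limit.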

Compound 3, apparent permeability: > 1000 10^-6 cm/s
Compound 3 was reported as a limit (the forecaster's own chance of this, stated with the estimate: 80%); the middle value lies on the limit itself.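

For the compounds shown here, compound 3, like compound 1 and compound 2, is reported in this assay only as a limit and not as a number, so no step among the three can be read in size or direction: the limit of > 1000 10^-6 cm/s in this assay, at which 3 of the 3 values shown sit.

From the compounds shown here alone, how far these three compounds really differ in how fast they cross the layer stays open.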